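Benzyl-type substitution on the shared core: pyridyl and methoxypyridyl variants

The source may hold more compounds than are shown below. What is called first, only, known or untested is meant among the compounds shown, and "the series" means these compounds.

Measured so far, in an assay on HEK293 cells for agonist activity at Toll-like receptor 8 (Homo sapiens), read by a luciferase reporter, with a stated time of 6 h; a higher number here means that more compound is needed for the effect, a lower number that less compound is needed:
- compound 1 `CCCCNc1nc(N)nc2ccn(Cc3ccccc3)c12`: > 25 uM, a limit of the assay rather than a number.
- compound 2 `CCCCNc1nc(N)nc2ccn(Cc3ccccn3)c12`: > 25 uM, again only a limit.
- compound 3 `CCCCNc1nc(N)nc2ccn(Cc3cccnc3)c12`: > 25 uM, again only a limit.

Compound 1 stands at the limit, as do both others; nothing in the numbers separates the three. The step that the two limits leave unreadable from compound 1 to compound 2 and the step that the two limits leave unreadable from compound 1 to compound 3 cannot be read, and the same holds for a step that the two limits leave unreadable from compound 2 to compound 3. The one thing the set shows is the limit of > 25 uM in this assay, at which 3 of the 3 values shown sit, so no ring at this position has yet produced a readable value.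

Compound 4 `CCCCNc1nc(N)nc2ccn(Cc3ncccc3OC)c12` takes the change (3-methoxypyridin-2-yl in place of phenyl on a saturated chain carbon bound to an aromatic nitrogen). For the measured compounds named here, the measured steps bear on it only loosely: both the pyridin-2-yl and pyridin-3-yl replacements left the value at the limit, and the extra methoxy group has no precedent. The expectation is therefore that compound 4 is most likely to return a limit again, with a modest chance of a readable value, so the estimated step that the limit leaves unreadable from compound 1 to compound 4 is set near nil. Compound 4 is estimated at 30 uM, within 8 uM to 100 uM.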

Compound 4, minimum effective concentration: 0.59 uM
For compound 4 the middle estimate is 51-fold (1.71 log units) above the measured one; measured number below the stated range.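

In this assay, this position on a saturated chain carbon bound to an aromatic nitrogen gives its first readable value with 3-methoxypyridin-2-yl, and the change from phenyl is an at least 42-fold lower number from compound 1 to compound 4 (1.62 log units; beyond the scatter). The closest comparison isolates methoxy in place of hydrogen on an aromatic carbon, an at least 42-fold lower number from compound 2 to compound 4 (1.62 log units; beyond the scatter), so within this pair the readable value appears only once the methoxy group is present on the pyridin-2-yl ring. The comparison with the other pyridine is an at least 42-fold lower number from compound 3 to compound 4 (1.62 log units; beyond the scatter), and compound 4 thus stands apart from the rest of the set, which otherwise sits at one assay limit: the limit of > 25 uM in this assay, at which 3 of the 4 values shown sit.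

On these data alone, whether a methoxyphenyl group would give a similar result, and whether ethoxy, hydroxy or chlorine in place of methoxy would keep a value close to that of compound 4 at 0.59 uM, stays open. As far as these compounds go, the steps among compound 1, compound 2 and compound 3 cannot be read, and the steps to compound 4 are bounded on one side only, so their full size also stays open.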